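This account rests on a few compounds, and the source may have more. Where it says the series, first, only, none or still open, it means among the compounds named here.

Two members of the series have numbers in a functional assay on SK-MEL-2 cells (Homo sapiens) for cytotoxicity, read by sulforhodamine B assay, with a stated time of 2 days, tested at 100 uM; a higher number here means more inhibition at the concentration tested (going by the name of the read-out), a lower number less inhibition. Compound 1 `COc1cccc(-c2nc3c(-c4ccco4)n[nH]c3c(=O)n2NC(=O)c2cccnc2)c1` gives 34.1% in this assay. Compound 2 `O=C(Nn1c(-c2cccc([N+](=O)[O-])c2)nc2c(-c3ccco3)n[nH]c2c1=O)c1ccccc1` gives 23% in this assay, the lower of the two, with compound 1 standing higher by a gap beyond the scatter. Compound 3 `COc1cccc(-c2nc3c(-c4ccco4)n[nH]c3c(=O)n2NC(=O)c2ccccc2)c1` is not yet measured; it differs from compound 2 by methoxy in place of nitro on an aromatic carbon. For the measured compounds named here, no measured pair shows this exact change, so its effect is unknown; a modest upward step is expected because compound 1 carries the 3-methoxyphenyl and gives 34.1% in this assay. The step of a number 8 percentage points higher from compound 2 to compound 3 (within the scatter) is expected to be small and upward. Compound 3 is estimated at 31%, within 16% to 46%.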

Compound 3, a percentage reported as inhibition, at one concentration (the size of the read-out at that concentration, not a potency): 43.2%
Compound 3: middle estimate off by 12.2 percentage points, on the low side, within the range that was stated.
By their numbers in this assay, from the lowest: compound 2; then compounds 1 and 3 (each within the scatter of the next).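

In this assay, for the compounds shown here, the exchange of 3-nitrophenyl for 3-methoxyphenyl gives the first single-place comparison at this aromatic carbon, a number 20.2 percentage points higher from compound 2 to compound 3 (beyond the scatter) with the rest of the structure unchanged, so the read-out responds to the group placed here. Phenyl in place of pyridin-3-yl on the carbonyl carbon gives a number 9.1 percentage points higher from compound 1 to compound 3 (within the scatter) and so leaves that exchange unresolved.

From the compounds shown here alone, how an amine or a carboxylic acid on this aromatic carbon would read remains open, as does whether the nitro-to-methoxy step holds with pyridin-3-yl on the carbonyl carbon. Nothing available explains either step.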